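Replacing Methylsulfanyl with Cyano on a Benzoxazole-type Core

The source may report more compounds than this note shows. Statements on the series, on what has been measured and on what is new or still open speak of the compounds shown alone.

Measured so far:
Compound 1, `CSc1ccccc1-c1nc2ncccc2o1`: 21%
Compound 2, `O=[N+]([O-])c1ccc(-c2nc3cccnc3o2)cc1`: 5%

Both compounds were tested in a functional assay on the whole organism for inhibition, with Rattus norvegicus as the target, at a dose of 30 mg/kg; on this read-out lower numbers stand for less inhibition and higher numbers for more inhibition at the one dose given (going by the name of the read-out). Compound 1 gives 21%, the higher of the two numbers. Compound 2 gives 5%, and the gap between the two lies beyond the usual scatter of this kind of measurement, so compound 1 does stand above compound 2 on this read-out. Within the data shown here, no step between closely related measured compounds is available, so there is nothing yet to say about how a single change on the outer ring shifts the number.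

Compound 3, `N#Cc1ccccc1-c1nc2ncccc2o1`, has not been measured. It differs from compound 1 in one place: cyano in place of methylsulfanyl on an aromatic carbon. The cyano group sits on the same aromatic carbon that carried the methylsulfanyl group in compound 1. Among the measured compounds shown here, with only two measured compounds, neither sharing this change, the expected size of the step is uncertain; a small drop or no step beyond the scatter seems the most likely outcome, and the step from compound 1 to compound 3 is estimated at a number 7 percentage points lower from compound 1 to compound 3 (within the scatter). Compound 3 is therefore expected to give about 14%, within a range of 2% to 30%.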

Compound 3, a percentage reported as inhibition, in the whole organism at one dose (the size of the read-out at that dose, not a potency): 62%
Compound 3: the middle estimate sits 48 percentage points below what was measured; measured number outside the range, above it.
By their numbers in this assay, from the lowest: compound 2; then compound 1; then compound 3.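

In this assay, cyano in place of methylsulfanyl on an aromatic carbon gives a number 41 percentage points higher from compound 1 to compound 3 (beyond the scatter), which shows that the number is sensitive to the group held at this position of the six-membered aromatic ring. The change is not one of size or of the simple counts: each group has 2 heavy atoms, no ring, 0 hydrogen-bond donors, 1 hydrogen-bond acceptor and no net charge. What differs is the atoms and bonds, with a sulfur leaving and a nitrogen joined by a triple bond entering, and no measurement here bears on why this swap moves the number.

The compounds shown leave open whether the higher number belongs to cyano in particular or would also appear with another group on the same carbon, such as an amine, a carboxylic acid or a longer chain like ethylsulfanyl. They also leave open whether the same swap would give a similar step at another dose or on a compound that differs elsewhere.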